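The compounds below may be only part of what the source reports. "The series", "measured", "known", "first", "only" and "open" are said of these compounds alone.

Compound 1 `N#CC1CN1C(=O)Nc1ccc(F)cc1` gives 1900 nM in a functional assay on MCF7 cells (Homo sapiens) for inhibition; on this read-out lower numbers stand for stronger inhibition and higher numbers for weaker inhibition.
Compound 2 `N#CC1CN1C(=O)Nc1ccccc1` gives 2900 nM in this assay.

Compound 2 stands with the highest of the two numbers, compound 1 being nearest a 1.5-fold higher number from compound 1 to compound 2 (0.18 log units; within the scatter). Compound 3 `N#CC1CN1C(=O)Nc1ccc(S(N)(=O)=O)cc1` has not been measured; it carries sulfamoyl in place of hydrogen on an aromatic carbon. For the measured compounds named here, the only measured step, from compound 1 to compound 2, concerns a different group and stays within the scatter, so it offers little guidance on how a sulfamoyl group will behave. Going by the values given here, with no step bearing directly on this change, no movement beyond the scatter is expected, and for compound 3 the estimate is a 1.0-fold higher number from compound 2 to compound 3 (0.01 log units; within the scatter). Compound 3 is therefore expected at 3000 nM, within 800 nM to 12000 nM.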

Compound 3, half-maximal inhibitory concentration: > 15000 nM
Compound 3: no number, only a limit; the forecaster's own chance of this, stated with the estimate: 10%; middle value at least 5.0-fold (0.69 log units) from the limit.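

Hydrogen and fluoro on this aromatic carbon gave numbers within the scatter of each other, so the earlier compounds showed no sensitivity to the change there. Sulfamoyl shows that this position does respond in this assay: sulfamoyl in place of hydrogen gives an at least 5.1-fold higher number from compound 2 to compound 3 (0.71 log units; beyond the scatter), and sulfamoyl in place of fluoro gives an at least 7.8-fold higher number from compound 1 to compound 3 (0.89 log units; beyond the scatter). Compound 3 gives only a limit of the assay, not a number: the limit of > 15000 nM in this assay, at which 1 of the 3 values shown sits.

The compounds shown leave open how large the loss really is. They also leave open whether an amine, a carboxylic acid or a methyl group here would behave like sulfamoyl or like fluoro.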